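The source may hold more compounds than are shown below. What is called first, only, known or untested is meant among the compounds shown, and "the series" means these compounds.

In a functional assay on P388 cells (Mus musculus) for antiproliferative activity, read by colorimetric assay and MTT assay (a lower number here means a stronger inhibitor, a higher number a weaker inhibitor), three compounds have been measured. Compound 1 `COc1ccc(S(=O)(=O)Nc2cccc3cc(O)[nH]c23)cc1` gives 0.11 ug/mL, compound 2 `O=S(=O)(Nc1cccc2cc(O)[nH]c12)c1ccc(Cl)cc1` gives 2.2 ug/mL, and compound 3 `Nc1ccc(S(=O)(=O)Nc2cccc3cc[nH]c23)cc1` gives 14 ug/mL. Compound 3 thus has the highest number of the three, beyond the scatter from both others and nearer to compound 2 than to compound 1.

Compound 4 `Nc1ccc(S(=O)(=O)Nc2cccc3cc(O)[nH]c23)cc1` differs from compound 3 in one place, with hydroxy in place of hydrogen on an aromatic carbon. Within the data shown here, no measured pair isolates this change. Among the measured compounds shown here, the only measured step, a 20-fold higher number from compound 1 to compound 2 (1.30 log units; beyond the scatter), is large, but it is chloro in place of methoxy on an aromatic carbon and so bears on the change only indirectly. It shows that the other substituent can move the number considerably when the hydroxy is present. Compound 1 and compound 2 carry the hydroxy that compound 3 lacks, but they also differ from compound 3 in that other substituent, so their gaps to it are not clean measures of the hydroxy. Even so, a large step to a lower number is expected in this assay, since compound 2 at 2.2 ug/mL and compound 1 at 0.11 ug/mL both lie well under compound 3. The expected change is a 35-fold lower number from compound 3 to compound 4 (1.54 log units; beyond the scatter). For compound 4 the estimated value is 0.4 ug/mL, with an expected range from 0.06 ug/mL to 3 ug/mL.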

Compound 4, half-maximal inhibitory concentration: 1.2 ug/mL
Compound 4: the middle estimate sits 3.0-fold (0.48 log units) below what was measured; measured number inside the range.
By their numbers in this assay, from the lowest: compound 1; then compounds 4 and 2 (each within the scatter of the next); then compound 3.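

In this assay, the step from hydrogen to hydroxy on this aromatic carbon of the five-membered ring, next to the ring nitrogen, can now be read directly with the amino group held fixed: a 12-fold lower number from compound 3 to compound 4 (1.07 log units; beyond the scatter). Among these compounds, this shows that the hydroxy alone goes with a large change in the number, which the earlier compounds could only suggest, as they also differed from compound 3 in the other substituent. With the hydroxy present, the comparison of that other substituent also sharpens: amino in place of methoxy gives an 11-fold higher number from compound 1 to compound 4 (1.04 log units; beyond the scatter), whereas amino in place of chloro gives a 1.8-fold lower number from compound 2 to compound 4 (0.26 log units; within the scatter), so compound 4 and compound 2 cannot be told apart in this assay, and methoxy alone separates from the other two. No measurement here explains any of these steps.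

The compounds shown leave open whether the hydroxy step keeps its size when methoxy or chloro replaces the amino group. They also leave open how a methyl group, a fluorine atom or a carboxylic acid at the hydroxy position would compare with hydroxy.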